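Replacing a Side Group with Piperidine

A few compounds are considered here, and "the series" means these few. Any claim that something is new, unique, unknown or untested is made for them only; others in the source may bear on it.

- compound 1 `Cc1cc(=O)c2c(O)cc(OCc3ccc(Br)cc3)c([C@H]3CCN(C)C[C@H]3O)c2o1` gives (14%)
- compound 2 `Cc1cc(=O)c2c(O)c(CN3CCN(C(=O)OC(C)(C)C)CC3)c(O)c([C@H]3CCN(C)C[C@H]3O)c2o1` gives (16%)
- compound 3 `Cc1cc(=O)c2c(O)c(CN3CCCC3CO)c(O)c([C@H]3CCN(C)C[C@H]3O)c2o1` gives (22%)

The three compounds were tested in a functional assay on MCF7 cells (Homo sapiens) for inhibition, read by MTT assay, with a stated time of 48 h, tested at 10 uM (on this read-out higher numbers stand for more inhibition of growth at the one concentration tested and lower numbers for less inhibition of growth), and all gave low numbers. Compound 3 (22%) lies within the usual scatter of both compound 2 (16%) and compound 1 (14%), so it cannot be separated from either.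

The next compound to be tested in this assay is compound 4 `Cc1cc(=O)c2c(O)c(CN3CCCCC3)c(O)c([C@H]3CCN(C)C[C@H]3O)c2o1`. It keeps the core of compound 3 and changes one group, with piperidin-1-yl in place of 2-(hydroxymethyl)pyrrolidin-1-yl on a saturated chain carbon bound to an aromatic carbon.

For the measured compounds named here, no two measured compounds differ in only one place, so the data give no direct guide to the size of this step. Compound 2 (16%) carries a different group on that same chain carbon and still stays within the scatter of compound 3. No step beyond the scatter is therefore expected, and the estimated change is small (a number 2 percentage points lower from compound 3 to compound 4 (within the scatter)). Compound 4 is expected to give about 20% (range 7% to 38%).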

Compound 4, percent growth inhibition at one concentration: 15%
Estimate against measurement, compound 4: 5 percentage points above; measured number inside the range.
By their numbers in this assay, from the lowest: compounds 1, 4, 2 and 3 (each within the scatter of the next).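

In this assay, for the compounds shown here, the exchange of 2-(hydroxymethyl)pyrrolidin-1-yl for piperidin-1-yl on a saturated chain carbon bound to an aromatic carbon gives a number 7 percentage points lower from compound 3 to compound 4 (within the scatter) and is the first step that can be read directly at this position. The hydroxymethyl group can leave and the five-membered ring can give way to a six-membered ring without a step beyond the scatter. Both alterations travel together in this one step, and the pair does not separate them. Nothing measured here offers an explanation for this step.

The compounds shown leave open how plain pyrrolidin-1-yl would read on this chain carbon, which would separate the ring change from the loss of hydroxymethyl. Also open, on these data alone, is whether another amine, such as morpholin-4-yl or dimethylamino, would give a step beyond the scatter.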